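Swapping an Acetyl for a Phenyl on the Urea Nitrogen

The source may hold more compounds than are shown below. What is called first, only, known or untested is meant among the compounds shown, and "the series" means these compounds.

Compound 1 `CC(=O)NC(=O)Nc1cccc(NC(=O)CBr)c1` is one of three related bromoacetamides for which a result is known. In a functional assay on CCRF-CEM cells (Homo sapiens) for cytotoxicity, read by MTT assay, with a stated time of 72 h (a lower number here means a stronger inhibitor, a higher number a weaker inhibitor), compound 1 gives 3200 nM, the second highest of the three numbers: compound 2 `CC(=O)NC(=O)Nc1cccc(NC(=O)C(C)Br)c1` gives 10600 nM and compound 3 `CC(Br)C(=O)NC(=O)Nc1cccc(NC(=O)C(C)Br)c1` gives 1340 nM. The steps seen so far, a 3.3-fold higher number from compound 1 to compound 2 (0.52 log units; beyond the scatter) and a 7.9-fold lower number from compound 2 to compound 3 (0.90 log units; beyond the scatter), both concern the saturated carbon bound to the bromine atom, not the urea nitrogen. Compound 4 `O=C(CBr)Nc1cccc(NC(=O)Nc2ccccc2)c1` differs from compound 1 only there: phenyl in place of acetyl on an amide-type nitrogen. Going by the values given here, no measured step touches this kind of change, so there is no basis for expecting a shift beyond the scatter in either direction. Compound 4 is therefore expected to give about 3000 nM, between 900 nM and 10000 nM, which means an estimated step of a 1.1-fold lower number from compound 1 to compound 4 (0.03 log units; within the scatter).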

Compound 4, half-maximal inhibitory concentration: 860 nM
Beside the measured number, compound 4's estimate is 3.5-fold (0.54 log units) above it; the whole stated range lies above it.
By their numbers in this assay, from the lowest: compounds 4 and 3 (each within the scatter of the next); then compound 1; then compound 2.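

The urea nitrogen is not a silent position: in this assay, phenyl in place of acetyl on this amide-type nitrogen gives a 3.7-fold lower number from compound 1 to compound 4 (0.57 log units; beyond the scatter) with the bromoacetamide part unchanged. Going by these compounds alone, the earlier steps changed only the saturated carbon bound to the bromine atom, so this is the first sign that the group on the urea nitrogen also moves the number. No measured evidence here accounts for the shift. As far as these compounds go, whether the aromatic ring itself matters stays open, and a cyclohexyl ring or a longer alkyl chain on the same nitrogen could help to settle it.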